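This account rests on a few compounds, and the source may have more. Where it says the series, first, only, none or still open, it means among the compounds named here.

Working notes on the series. Of the compounds shown here, two have a number so far in a functional assay (Homo sapiens) for antiproliferative activity, read by resazurin assay, with a stated time of 48 h, tested at 20 uM; on this read-out lower numbers stand for a weaker effect and higher numbers for a stronger effect at the one concentration tested. Compound 1 `COc1cc(OC)c2c(=O)cc(-c3ccc(OCCBr)cc3)oc2c1` gives 20% in this assay. For the measured compounds named here, compound 2 `COc1cc(OC)c2c(=O)cc(-c3ccc(OCCN)cc3)oc2c1` gives 70% in this assay, the higher of the two numbers; the single measured step, a number 50 percentage points higher from compound 1 to compound 2 (beyond the scatter), shows that the end of the ether chain is where the series so far changes most.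

Compound 3 `COc1cc(OC)c2c(=O)cc(-c3ccc(OCC(O)CN4CCCC4)cc3)oc2c1` is not yet measured. Relative to compound 2 the change is 1-hydroxy-2-(pyrrolidin-1-yl)ethyl in place of aminomethyl on a saturated chain carbon bound to an oxygen on an aromatic ring. Going by the values given here, no measured pair tests this change, and the only step available, from compound 1 to compound 2, concerns a different exchange at the same chain end, so it bears on compound 3 only in showing that this position is sensitive. The nitrogen at the chain end is kept in compound 3, which is the feature that distinguished compound 2 from compound 1, so a number near that of compound 2 is expected, with the step of a number 5 percentage points lower from compound 2 to compound 3 (within the scatter) expected to be small in this assay. The estimate for compound 3 in this assay is 65%, with a range from 40% to 85%.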

Compound 3, a percentage reported as inhibition, at one concentration (the size of the read-out at that concentration, not a potency): 57%
The estimate for compound 3 lay 8 percentage points above the measured number; the range from low to high includes it.
By their numbers in this assay, from the lowest: compound 1; then compound 3; then compound 2.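

In this assay, 1-hydroxy-2-(pyrrolidin-1-yl)ethyl in place of aminomethyl on a saturated chain carbon bound to an oxygen on an aromatic ring gives a number 13 percentage points lower from compound 2 to compound 3 (beyond the scatter), so this position tolerates a much larger group carrying a five-membered non-aromatic ring, at a modest loss of effect. The same group in place of bromomethyl gives a number 37 percentage points higher from compound 1 to compound 3 (beyond the scatter), so the nitrogen-bearing chain ends of compound 2 and compound 3 both stand clearly above the bromo chain end of compound 1, and neither compound goes against this among the three shown. No measurement at hand offers an explanation for either step.

The change from compound 2 to compound 3 alters the chain length, adds a hydroxy group and replaces the primary amine with a pyrrolidine ring all at once, so the compounds shown cannot assign the modest loss to any one of these; a 2-(pyrrolidin-1-yl)ethoxy chain without the hydroxy group would separate them. As far as these compounds go, whether a piperidine, a morpholine or a carboxylic acid at the chain end would hold the effect also stays open, and each number shows only the size of the effect at a single concentration.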